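Working notes: from compound 2 to compound 3

This account rests on a few compounds, and the source may have more. Where it says the series, first, only, none or still open, it means among the compounds named here.

Measured so far in a functional assay on PANC-1 cells (Homo sapiens) for cytotoxicity, read by WST assay, with a stated time of 24 h (on this read-out lower numbers stand for stronger inhibition and higher numbers for weaker inhibition), as follows
- compound 1 `O=C(/C=C\CCCCCCc1ccccc1)N1CCCCC1` gives > 100000 nM as a limit
- compound 2 `O=C(CCCCCCCCCc1ccccc1)N1CCCCC1` gives > 100000 nM as a limit

In this assay compound 2 gives > 100000 nM as a limit and not a number. Among the compounds with values here, the series so far offers only the limit of > 100000 nM in this assay, at which 2 of the 2 values shown sit, as its evidence. Compound 3 `O=C(CCCCCCCCc1ccc(O)cc1)N1CCCCC1` brings 4-hydroxyphenyl in place of benzyl on a saturated chain carbon, eight bonds along the chain from a carbonyl carbon with 4-hydroxyphenyl in place of benzyl on a saturated chain carbon, eight bonds along the chain from a carbonyl carbon. A small step toward stronger inhibition is expected, possibly none beyond the scatter. The estimated change is an at least 1.1-fold lower number from compound 2 to compound 3 (0.04 log units; that floor lies within the scatter) in this comparison. For compound 3 the expected value is 90000 nM with an estimated range from 40000 nM to 150000 nM in this assay.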

Compound 3, half-maximal inhibitory concentration: > 100000 nM
Compound 3: only a limit was reported; the forecaster's own chance of this, stated with the estimate: 65%; at least 1.1-fold (0.04 log units) between middle value and limit.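

In this assay compound 3 gives > 100000 nM, a limit and not a number. Compound 2 also stands only as a limit, and no step can be read between compound 2 and compound 3. On these data alone, whether any compound of this series reaches a measurable value in this assay stays open.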